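Aryl halogen exchange on a carbonyl carbon in a shared core

The source may report more compounds than this note shows. Statements on the series, on what has been measured and on what is new or still open speak of the compounds shown alone.

Of the compounds shown here, three built on a shared core have been measured in a functional assay on BCG823 cells (Homo sapiens) for inhibition, read by MTT assay, with a stated time of 72 h; on this read-out higher numbers stand for weaker inhibition and lower numbers for stronger inhibition. Compound 1 `CN(C(=O)NC(=O)c1ccc(Cl)cc1Cl)c1nc(C(F)(F)F)c(C(=O)N/N=C/c2cccc(C(F)(F)F)c2)s1` gives 6.11 ug/mL in this assay. Compound 2 `CN(C(=O)NC(=O)c1ccc(F)c(F)c1)c1nc(C(F)(F)F)c(C(=O)N/N=C/c2ccccc2C(F)(F)F)s1` gives 3.66 ug/mL in this assay. Compound 3 `CN(C(=O)NC(=O)c1ccc(F)c(F)c1)c1nc(C(F)(F)F)c(C(=O)N/N=C/c2cccc(C(F)(F)F)c2)s1` gives 4.46 ug/mL in this assay. The three numbers all lie within the usual scatter of one another, so no ordering among them can be read from these data.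

Two single changes connect the measured compounds. From compound 3 to compound 1 the change is 2,4-dichlorophenyl in place of 3,4-difluorophenyl on a carbonyl carbon, and it produced a 1.4-fold higher number from compound 3 to compound 1 (0.14 log units; within the scatter). Compound 2 and compound 3 share the same atoms joined differently: 2-(trifluoromethyl)phenyl in place of 3-(trifluoromethyl)phenyl on a carbon with a double bond to nitrogen, which produced a 1.2-fold higher number from compound 2 to compound 3 (0.09 log units; within the scatter).

Compound 4 `CN(C(=O)NC(=O)c1ccc(Cl)cc1Cl)c1nc(C(F)(F)F)c(C(=O)N/N=C/c2ccccc2C(F)(F)F)s1` has not yet been measured in this assay. It differs from compound 2 by 2,4-dichlorophenyl in place of 3,4-difluorophenyl on a carbonyl carbon. Among the measured compounds shown here, this is the same change as the one from compound 3 to compound 1, made at the same place, so that change has a single measured precedent here. Because that precedent, a 1.4-fold higher number from compound 3 to compound 1 (0.14 log units; within the scatter), stayed within the scatter, the step expected for compound 4 is likewise small, namely a 1.4-fold higher number from compound 2 to compound 4 (0.14 log units; within the scatter). On that basis compound 4 is estimated at 5 ug/mL in this assay, with an expected range from 2.5 ug/mL to 10 ug/mL. The estimate rests on one pair alone, and the measurement will show whether the change behaves the same way a second time.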

Compound 4, half-maximal inhibitory concentration: 5.73 ug/mL
Compound 4: the middle estimate sits 1.1-fold (0.06 log units) below what was measured; the range from low to high includes it.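

In this assay, the halogen exchange on the carbonyl carbon gave a 1.6-fold higher number from compound 2 to compound 4 (0.19 log units; within the scatter), and this second instance agrees with the first: the same change on two cores in this assay, a 1.4-fold higher number (0.14 log units; within the scatter) from compound 3 to compound 1 and a 1.6-fold higher number (0.19 log units; within the scatter) from compound 2 to compound 4, 1.1-fold (0.06 log units) apart, within the scatter of two such steps. The move of the trifluoromethyl group from the 3-(trifluoromethyl)phenyl to the 2-(trifluoromethyl)phenyl form on the carbon with a double bond to nitrogen gave a 1.1-fold lower number from compound 1 to compound 4 (0.03 log units; within the scatter), and it too agrees with its earlier instance: the same change on two cores in this assay, a 1.2-fold higher number (0.09 log units; within the scatter) from compound 2 to compound 3 and a 1.1-fold higher number (0.03 log units; within the scatter) from compound 4 to compound 1, 1.1-fold (0.06 log units) apart, within the scatter of two such steps. This shows that, for these four compounds, each change stays small when carried from one core to the other, but it does not establish a direction for either change or any real effect of them, and two cores that differ only in these two places say nothing about how the changes would behave on a more distant core.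

The groups on the carbonyl carbon shown here are only the 2,4-dichlorophenyl and 3,4-difluorophenyl groups, which leaves open how an unsubstituted phenyl, or a phenyl bearing a methoxy group, an amine or a carboxylic acid, would read in this assay. On these data alone, on the carbon with a double bond to nitrogen, it also remains open whether a phenyl bearing a nitrile in place of trifluoromethyl would give a step beyond the scatter.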